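Swapping Chloro for Cyano on a Cytotoxic Enone

A few compounds are considered here, and "the series" means these few. Any claim that something is new, unique, unknown or untested is made for them only; others in the source may bear on it.

Measured so far in a functional assay on K562 cells (Homo sapiens) for cytotoxicity, read by MTT assay, with a stated time of 24 h; a lower number here means a stronger inhibitor, a higher number a weaker inhibitor:

- compound 1 `COc1ccc(/C=C2\CN(C)C/C(=C\c3ccccc3F)C2=O)cc1` gives 18400 nM as its half-maximal inhibitory concentration
- compound 2 `COc1cc(/C=C2\CN(C)C/C(=C\c3ccccc3F)C2=O)cc(OC)c1OC` gives 4340 nM as its half-maximal inhibitory concentration
- compound 3 `COc1cc(/C=C2\CN(C)C/C(=C\c3ccc(Cl)cc3)C2=O)cc(OC)c1` gives 13300 nM as its half-maximal inhibitory concentration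

In this assay compound 3, at 13300 nM, cannot be told apart from compound 1, since the two values lie within the scatter of each other. Compound 2 gives a lower number, beyond the scatter of compound 3.

The next compound, compound 4 `COc1cc(/C=C2\CN(C)C/C(=C\c3ccc(C#N)cc3)C2=O)cc(OC)c1`, keeps the shared core of compound 3 and carries cyano in place of chloro on an aromatic carbon, para to a large group. This turns 4-chlorophenyl into 4-cyanophenyl. Within the data shown here, no measured pair shows this exchange on its own, so the expectation starts from compound 3 at 13300 nM and assumes no step beyond the scatter, in either direction. The estimated change is a 1.2-fold lower number from compound 3 to compound 4 (0.08 log units; within the scatter) and is expected to stay small. Compound 4 is expected at 11000 nM (estimated range 4500 nM to 27000 nM).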

Compound 4, half-maximal inhibitory concentration: 4650 nM
The estimate for compound 4 lay 2.4-fold (0.37 log units) above the measured number; the range from low to high includes it.
By their numbers in this assay, from the lowest: compounds 2 and 4 (each within the scatter of the next); then compounds 3 and 1 (each within the scatter of the next).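

In this assay the exchange of chloro for cyano, which turns 4-chlorophenyl into 4-cyanophenyl, gives a 2.9-fold lower number from compound 3 to compound 4 (0.46 log units; beyond the scatter) and so lies beyond the scatter, if only modestly. This is the only pair shown that differs in one place, and it makes the aromatic carbon para to a large group the one position where the group carried can be seen to shift the number. Nothing measured here accounts for the step, and its cause stays unknown.

On these data alone, whether cyano is unusual at this position remains open, since a single exchange cannot show how a carboxylic acid, an amine or a primary amide would behave on the same carbon. Also open, as far as these compounds go, is whether the same swap would give a similar step with the aromatic ring on the other side of the shared core changed.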